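Working notes: from compound 3 to compound 4

The source may report more compounds than this note shows. Statements on the series, on what has been measured and on what is new or still open speak of the compounds shown alone.

Measured in a toxicity assay on Vero cells (Chlorocebus sabaeus) for cytotoxicity, read by MTT assay; on this read-out higher numbers stand for weaker inhibition and lower numbers for stronger inhibition:
- compound 1 (`COC(=O)NC(=O)c1ccsc1NC(=O)c1ccc(S(=O)(=O)N2CCC2)cc1`) gives 17.5 ug/mL
- compound 2 (`COC(=O)NC(=O)c1ccsc1NC(=O)c1ccc(S(=O)(=O)N2CCC(OC)CC2)cc1`) gives 18 ug/mL
- compound 3 (`COC(=O)NC(=O)c1ccsc1NC(=O)c1ccc(S(=O)(=O)N2CCC(c3ccccc3)CC2)cc1`) gives "nd" (no result reported)

Compound 3 has no number in this assay and so holds no place relative to the other two compounds. The next compound to be read is compound 4 (`COC(=O)NC(=O)c1ccsc1NC(=O)c1ccc(S(=O)(=O)N(C)C)cc1`). The structural change is dimethylamino in place of 4-phenylpiperidin-1-yl on a sulfonyl sulfur.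

With no value at its starting point, this change cannot be sized as a step from compound 3, and no direction can be assigned to it. Going by the values given here, the only measured step that bears on it is a change at the same sulfonyl sulfur, with 4-methoxypiperidin-1-yl in place of azetidin-1-yl: a 1.0-fold higher number from compound 1 to compound 2 (0.01 log units; within the scatter). That step lies within the scatter, but it is a single step and does not involve either group in the present change. The expectation therefore rests on the two measured values, with compound 1 at 17.5 ug/mL and compound 2 at 18 ug/mL. No shift beyond the scatter from these values is expected, although the range is kept wide.

Compound 4 is estimated at 18 ug/mL, with an expected range from 8 ug/mL to 40 ug/mL.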

Compound 4, half-maximal inhibitory concentration: 16.2 ug/mL
Estimate against measurement, compound 4: 1.1-fold (0.05 log units) above; the range from low to high includes it.
By their numbers in this assay, from the lowest: compounds 4, 1 and 2 (each within the scatter of the next).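

In this assay, the sulfonyl sulfur now carries dimethylamino, a group with no ring, and the reading holds within the scatter against both ring-bearing amines: a 1.1-fold lower number from compound 2 to compound 4 (0.05 log units; within the scatter), and a 1.1-fold lower number from compound 1 to compound 4 (0.03 log units; within the scatter). Where the earlier compounds offered a single comparison between two ring-bearing amines, azetidin-1-yl, 4-methoxypiperidin-1-yl and dimethylamino now cannot be told apart in this read-out, so across these three compounds the presence or size of a ring on the sulfonyl sulfur shows no effect beyond the scatter. No measurement at hand accounts for this flat reading.

On these data alone, the step from compound 3 to compound 4 cannot be read, since compound 3 has no number, so it remains open whether 4-phenylpiperidin-1-yl, with its added six-membered aromatic ring, would stay with the other three compounds. Also open, as far as these compounds go, is whether piperazin-1-yl, morpholin-4-yl or a chain bearing a carboxylic acid on the same sulfonyl sulfur would leave the number in the same place.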